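A few compounds are considered here, and "the series" means these few. Any claim that something is new, unique, unknown or untested is made for them only; others in the source may bear on it.

Measured compounds:
- compound 1 `CCCS(=O)(=O)Nc1ccc(F)c(C(=O)c2n[nH]c3ncc(-c4ccc(C)cc4)cc23)c1F`: 5.4%
- compound 2 `CCCS(=O)(=O)Nc1ccc(F)c(C(=O)c2n[nH]c3ncc(-c4cccc(OC)c4)cc23)c1F`: 6.3%
- compound 3 `CCCS(=O)(=O)Nc1ccc(F)c(C(=O)c2n[nH]c3ncc(-c4cccc(O)c4)cc23)c1F`: 2.2%

In an assay for binding affinity to dual specificity mitogen-activated protein kinase kinase 4 (Homo sapiens), read by KINOMEscan, tested at 100 nM (on this read-out lower numbers stand for a stronger effect and higher numbers for a weaker effect at the one concentration tested), compound 3 gives the lowest of the three numbers, yet none of its gaps to the others stands out: a number 3.2 percentage points lower from compound 1 to compound 3 (within the scatter) and a number 4.1 percentage points lower from compound 2 to compound 3 (within the scatter) are both within the scatter, so the three measured compounds cannot be ranked against one another on this read-out. For the measured compounds named here, the one earlier change at the same part of the molecule, a number 0.9 percentage points higher from compound 1 to compound 2 (within the scatter), also stayed within the scatter.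

Compound 4 `CCCS(=O)(=O)Nc1ccc(F)c(C(=O)c2n[nH]c3ncc(-c4cccc(N(C)C)c4)cc23)c1F` is the next step from compound 3. The change is dimethylamino in place of hydroxy on an aromatic carbon. Going by the values given here, no measured step removes a hydroxy or brings in a dimethylamino, so the nearest guide is the whole set of variations on the aromatic ring in this position, all of which left this assay essentially unchanged. On that basis no step beyond the scatter is expected from compound 3 to compound 4; the expected step is a number 2.3 percentage points higher from compound 3 to compound 4 (within the scatter). Compound 4 is therefore estimated at 4.5% in this assay, with a likely range from 1.5% to 12%.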

Compound 4, a percentage reported as activity, at one concentration (the size of the read-out at that concentration, not a potency): 26%
Estimate against measurement, compound 4: 21.5 percentage points below; measured number outside the range, above it.
By their numbers in this assay, from the lowest: compounds 3, 1 and 2 (each within the scatter of the next); then compound 4.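

In this assay this aromatic carbon, meta to a large group, is no longer a place where every variation stays within the scatter: the change to dimethylamino gives a number 23.8 percentage points higher from compound 3 to compound 4 (beyond the scatter) and replacing methoxy with dimethylamino gives a number 19.7 percentage points higher from compound 2 to compound 4 (beyond the scatter) while the wider swap of the whole aryl group gives a number 20.6 percentage points higher from compound 1 to compound 4 (beyond the scatter) as its step. Since 4-methylphenyl, 3-methoxyphenyl and 3-hydroxyphenyl cannot be ranked against one another, the series now divides into those three compounds on one side and 3-(dimethylamino)phenyl on the other, so the read-out at this position does respond to the group placed there. Nothing measured here accounts for this step.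

Still open, from the compounds shown here alone, is whether the step goes with the nitrogen or with the added carbons, which an amino or a methylamino group on the same aromatic carbon would help to separate. Also open, going by these compounds, is how a larger amine, such as a pyrrolidine or morpholine, or a carboxylic acid would read there, and how far a difference at one concentration carries over to potency.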